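The source may report more compounds than this note shows. Statements on the series, on what has been measured and on what is new or still open speak of the compounds shown alone.

Compound 2, `O=C(/C=C/c1cccc(O)c1)c1cccc(-n2cc(-c3ccccc3)[nH]c2=O)c1`, is measured in a functional assay on UO-31 cells (Homo sapiens) for inhibition (on this read-out lower numbers stand for stronger inhibition of growth and higher numbers for weaker inhibition of growth), and gives 2160 nM. Its only companion in the data is compound 1, `COc1cc(/C=C/C(=O)c2cccc(-n3cc(-c4ccccc4)[nH]c3=O)c2)ccc1O`, which in this assay gives 2180 nM. Within the data shown here, the one measured step, a 1.0-fold lower number from compound 1 to compound 2 (0.00 log units; within the scatter), changes the aryl group on the double-bonded chain carbon and leaves the two numbers indistinguishable. Compound 2 therefore holds the lowest of the two numbers, but only nominally, since the gap to compound 1 lies within the scatter.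

Compound 3, `O=C(/C=C/c1cccc(O)c1)c1cccc(-n2cc(-c3ccc(Cl)cc3)[nH]c2=O)c1`, keeps the chain and the core of compound 2 and differs by chloro in place of hydrogen on an aromatic carbon, the phenyl on the core becoming 4-chlorophenyl. Among the measured compounds shown here, no measured step touches this part of the molecule; the single step known concerns the other end of the chain and was itself flat. There is thus nothing in the data to support a shift in either direction, and the step of a 1.0-fold lower number from compound 2 to compound 3 (0.01 log units; within the scatter) is expected to stay within the scatter. For compound 3 the estimate in this assay is 2100 nM, with a range from 900 nM to 5000 nM.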

Compound 3, concentration for 50% growth inhibition: 550 nM
Compound 3: the middle estimate sits 3.8-fold (0.58 log units) above what was measured, outside the stated range (below it).
By their numbers in this assay, from the lowest: compound 3; then compounds 2 and 1 (each within the scatter of the next).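

Among these compounds, the phenyl on the core is the first part of the molecule seen to matter in (this assay): chloro in place of hydrogen, para to a large group on that ring, gives a clear change (a 3.9-fold lower number from compound 2 to compound 3 (0.59 log units; beyond the scatter)), while the only earlier step, at the other end of the chain, stayed flat (a 1.0-fold lower number from compound 1 to compound 2 (0.00 log units; within the scatter)). One added heavy atom, a chlorine, is thus enough to produce a modest but real step beyond the scatter, and it shows that this end of the molecule responds to substitution where the aryl change on the chain did not. Nothing at hand explains why this replacement lowers the number, so the step stands as an observation only.

With only hydrogen and chloro shown at this place, it remains open whether the step is particular to chloro or would also appear with fluoro, bromo, methoxy or an amine on the same carbon. As far as these compounds go, it is also open whether chloro would give a step of the same size on the 4-hydroxy-3-methoxyphenyl compound, compound 1.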